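The source may hold more compounds than are shown below. What is called first, only, known or untested is meant among the compounds shown, and "the series" means these compounds.

Working notes on the series. In a functional assay on HepG2 cells (Homo sapiens) for antiproliferative activity, read by MTT assay, with a stated time of 48 h (on this read-out lower numbers stand for stronger inhibition and higher numbers for weaker inhibition), compound 1 `CCn1c(C(=O)NCCN(C)C)ccc1C(CC)(CC)c1ccc(OCCC(O)(CC)CC)c(C)c1` gives 240 nM. Compound 2 `CCOc1ccc(NC(=O)c2ccc(C(CC)(CC)c3ccc(OCCC(O)(CC)CC)c(C)c3)n2CC)cc1` returns only a limit, > 50000 nM. For the measured compounds named here, the one measured step bearing on the next change is large: an at least 200-fold higher number from compound 1 to compound 2 (2.31 log units; beyond the scatter). Compound 3 `CCOC(=O)C(CC(=O)OC)NC(=O)c1ccc(C(CC)(CC)c2ccc(OCCC(O)(CC)CC)c(C)c2)n1CC` differs from compound 2 at the amide-type nitrogen: a group of 11 heavy atoms (7 carbon, 4 oxygen; no ring) in place of a group of 9 heavy atoms (8 carbon, 1 oxygen; one six-membered aromatic ring of carbon only), on an amide-type nitrogen. Compound 3, like compound 2, lacks the 2-(dimethylamino)ethyl group, whose replacement in compound 2 gave an at least 200-fold higher number from compound 1 to compound 2 (2.31 log units; beyond the scatter), so no recovery to the level of compound 1 is expected. The expected step is small, if any: an at least 2.0-fold lower number from compound 2 to compound 3 (0.30 log units; that floor lies within the scatter). The estimate for compound 3 is 25000 nM, with an expected range of 4000 nM to 60000 nM.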

Compound 3, half-maximal inhibitory concentration: > 50000 nM
Compound 3: only a limit was reported; the forecaster's own chance of this, stated with the estimate: 50%; middle value at least 2.0-fold (0.30 log units) from the limit.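

Working without a ring does not rescue this position: with the non-aromatic group of compound 3 on the amide-type nitrogen, the result is still an at least 200-fold higher number from compound 1 to compound 3 (2.31 log units; beyond the scatter). Among the compounds shown, both replacements of 2-(dimethylamino)ethyl, one with an aromatic ring and one with no ring, end at a limit and not at a number. The step from compound 2 to compound 3 cannot be read, because both values are limits: the limit of > 50000 nM in this assay, at which 2 of the 3 values shown sit.

Open, going by these compounds, is whether a 3-(dimethylamino)propyl, 2-aminoethyl or 2-hydroxyethyl group on this nitrogen would stay near compound 1. Which part of the 2-(dimethylamino)ethyl group carries the activity also stays unresolved.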